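Butyl compounds: 4-methoxyphenyl in place of 3-bromophenyl

The source may report more compounds than this note shows. Statements on the series, on what has been measured and on what is new or still open speak of the compounds shown alone.

Among the measured compounds shown here, in a functional assay on HT-29 cells (Homo sapiens) for antiproliferative activity, read by sulforhodamine B assay, with a stated time of 48 h (a lower number here means a stronger inhibitor, a higher number a weaker inhibitor), two compounds have numbers so far. Compound 1 (`CCN1CCN(c2ccc(S(=O)(=O)Oc3ccc(OC)cc3)cc2)C1=O`) gives 60000 nM as its reading. Compound 2 (`CCCCN1CCN(c2ccc(S(=O)(=O)Oc3cccc(Br)c3)cc2)C1=O`) gives 16000 nM as its reading, the lower of the two numbers, and its gap to compound 1 lies beyond the usual scatter. For the measured compounds named here, no step between measured compounds isolates a single change, so the series offers no direct guide yet.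

Next comes compound 3 (`CCCCN1CCN(c2ccc(S(=O)(=O)Oc3ccc(OC)cc3)cc2)C1=O`), not yet measured, which keeps the butyl chain of compound 2. The change is 4-methoxyphenyl in place of 3-bromophenyl on an oxygen and reads in words as 4-methoxyphenyl in place of 3-bromophenyl on an oxygen. Going by the values given here, the only measured compound with 4-methoxyphenyl is compound 1 at 60000 nM and this higher number points the expectation upward from compound 2, though only weakly. A modest move towards weaker inhibition is expected, namely a 1.9-fold higher number from compound 2 to compound 3 (0.27 log units; within the scatter) in this assay and so near the edge of the scatter. For compound 3 the estimated value is 30000 nM with an expected range from 10000 nM to 70000 nM in this measurement.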

Compound 3, half-maximal inhibitory concentration: 35000 nM
For compound 3 the middle estimate is 1.2-fold (0.07 log units) below the measured one; low and high end bracket the measured number.
By their numbers in this assay, from the lowest: compound 2; then compounds 3 and 1 (each within the scatter of the next).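

Among the compounds shown here, with the butyl chain held constant, 4-methoxyphenyl in place of 3-bromophenyl on an oxygen bonded to the sulfonyl sulfur gives a 2.2-fold higher number from compound 2 to compound 3 (0.34 log units; beyond the scatter) in this assay, the first single-place reading at this position and a modest step beyond the scatter. With 4-methoxyphenyl held constant, butyl in compound 3 against ethyl in compound 1 gives a 1.7-fold lower number from compound 1 to compound 3 (0.23 log units; within the scatter), a step within the scatter, so this pair does not separate the two chains. Nothing shown accounts for either step.

The step from 3-bromophenyl to 4-methoxyphenyl changes both the substituent and its place on the ring, and the compounds shown do not separate these two changes, which a 3-methoxyphenyl or 4-bromophenyl partner on the butyl chain could address. Also open, from the compounds shown here alone, is whether a chain longer than butyl, or an amine at the end of the chain, would give a step beyond the scatter at the chain position.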